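Sulfonyl series on DU-145 cells: aryl for benzyl

The source may hold more compounds than are shown below. What is called first, only, known or untested is meant among the compounds shown, and "the series" means these compounds.

Compound 1 `Cc1ccc(/C=C(\C(=O)c2ccc(Cl)cc2)S(=O)(=O)Cc2ccc(Cl)cc2Cl)s1` is the weaker of the two measured compounds: in a functional assay on DU-145 cells (Homo sapiens) for inhibition, read by trypan blue exclusion, with a stated time of 96 h (a lower number here means a stronger inhibitor of growth, a higher number a weaker inhibitor of growth), compound 1 gives 10000 nM, the highest of the two numbers shown. Its nearest neighbour in the set is compound 2 `COc1cc(OC)c(/C=C(/SCc2ccc(F)cc2)C(=O)c2ccc(Br)cc2)c(OC)c1`, which in this assay gives 1000 nM, a gap that lies beyond the scatter; the two structures differ in several places at once, so no single change can be read from that pair.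

Compound 3 `COc1ccc(S(=O)(=O)/C(=C/c2ccc(C)s2)C(=O)c2ccc(Cl)cc2)cc1` has not yet been measured in this assay. It differs from compound 1 in one place only: 4-methoxyphenyl in place of 2,4-dichlorobenzyl on a sulfonyl sulfur. The group that enters carries one hydrogen-bond acceptor where the leaving group carried none.

Nothing in the measured pair speaks directly to this change, so the step of a 1.7-fold lower number from compound 1 to compound 3 (0.22 log units; within the scatter) is expected to be small, if anything towards a lower number, and may well fall within the scatter. Compound 3 is therefore estimated at 6000 nM, with a range from 1500 nM to 25000 nM in this assay.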

Compound 3, concentration for 50% growth inhibition: 25000 nM
Compound 3: middle estimate off by 4.2-fold (0.62 log units), on the low side; low and high end bracket the measured number.
By their numbers in this assay, from the lowest: compound 2; then compound 1; then compound 3.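

The sulfonyl sulfur is now shown to be sensitive to the group it carries: in this assay, 4-methoxyphenyl in place of 2,4-dichlorobenzyl gives a 2.5-fold higher number from compound 1 to compound 3 (0.40 log units; beyond the scatter), a modest loss of growth inhibition. For the compounds shown here, this is the first single-place comparison, and the earlier pair could not show it because those two compounds differ in several places at once. No measurement at hand accounts for the step.

The change swaps a benzyl for a phenyl and replaces both chlorines with a methoxy group in one move, so the compounds shown leave open which part carries the step. A 4-methoxybenzyl or 2,4-dichlorophenyl group on the same sulfur would separate these parts.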